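Ethyl on the amide nitrogen of compound 1

The source may report more compounds than this note shows. Statements on the series, on what has been measured and on what is new or still open speak of the compounds shown alone.

Compound 1 `CCC1C(=O)N(C)c2cnc(-n3ccc4cc(C(N)=O)ccc43)nc2N1c1ccn(C)n1` stands in a functional assay on NCI-H1975 cells (Homo sapiens) for antiproliferative activity, read by CCK-8 assay, with a stated time of 72 h (on this read-out lower numbers stand for stronger inhibition of growth and higher numbers for weaker inhibition of growth), as "not active" (no number reported), with no number behind that word. Two related compounds do carry numbers: in this assay compound 2 `CC[C@@H]1C(=O)N(C)c2cnc(Nc3ccc(S(=O)(=O)NC4CCCC4)cc3)nc2N1C1CCCC1` gives 1710 nM, and compound 3 `CCCCNC(=O)c1ccc2c(ccn2-c2ncc3c(n2)N(C2CCCC2)[C@H](CC)C(=O)N3C)c1` gives 990 nM. Compound 3 shares with compound 4 a carboxamide bearing a chain on the amide nitrogen, yet it differs from compound 4 elsewhere too, so its value serves only as a loose anchor.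

Compound 4 `CCNC(=O)c1ccc2c(ccn2-c2ncc3c(n2)N(c2ccn(C)n2)C(CC)C(=O)N3C)c1` differs from compound 1 by ethyl in place of hydrogen on an amide-type nitrogen. Compound 1 offers no number against which to size this step. A modest move toward measurable inhibition in this assay is expected, though a further limit is possible. Compound 4 is expected to give 4000 nM, within 800 nM to 20000 nM.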

Compound 4, concentration for 50% growth inhibition: "not active" (no number reported)
Compound 4 has no reported number here; no gap can be computed for the estimate.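

Compound 1 and compound 4 both stand without a number, so no step can be read between them. On these data alone, whether ethyl in place of the amide hydrogen changes growth inhibition at all stays open. No measured evidence bears on this result.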